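Nitrobenzimidazole thioacetyl series: carbonyl substituent and HepG2 cytotoxicity

This account rests on a few compounds, and the source may have more. Where it says the series, first, only, none or still open, it means among the compounds named here.

Measured compounds in a functional assay on HepG2 cells (Homo sapiens) for cytotoxicity, read by MTT assay, with a stated time of 48 h; on this read-out higher numbers stand for weaker inhibition and lower numbers for stronger inhibition:
- compound 1, `O=C(CSCc1nc2cc([N+](=O)[O-])ccc2[nH]1)c1ccc(Cl)cc1`, gives 2650 nM
- compound 2, `NC(=O)CSCc1nc2cc([N+](=O)[O-])ccc2[nH]1`, gives 26900 nM
- compound 3, `NNC(=O)CSCc1nc2cc([N+](=O)[O-])ccc2[nH]1`, gives 18600 nM

Compound 3 holds the second highest number of the three. Its nearest neighbour is compound 2, and the step of a 1.4-fold lower number from compound 2 to compound 3 (0.16 log units; within the scatter) lies within the scatter, so the two are not ordered against each other. Its furthest neighbour is compound 1, and the step of a 7.0-fold higher number from compound 1 to compound 3 (0.85 log units; beyond the scatter) is beyond the scatter.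

Compound 4, `CC1=NN(C(=O)CSCc2nc3cc([N+](=O)[O-])ccc3[nH]2)C(=O)C1`, is not yet measured. The change from compound 3 is a group of 7 heavy atoms (4 carbon, 2 nitrogen, 1 oxygen; one five-membered non-aromatic ring with 2 hetero atoms) in place of a group of 2 heavy atoms (2 nitrogen; no ring), on a carbonyl carbon. Among the measured compounds shown here, two measured steps bear on it: a 10-fold higher number from compound 1 to compound 2 (1.01 log units; beyond the scatter) and a 7.0-fold higher number from compound 1 to compound 3 (0.85 log units; beyond the scatter) both show that a small nitrogen group on this carbonyl carbon, in place of the 4-chlorophenyl, gives a clearly higher number, while a 1.4-fold lower number from compound 2 to compound 3 (0.16 log units; within the scatter) shows that swapping one small nitrogen group for another changes little. For the measured compounds named here, no measured step covers a ring-bearing group of this kind on the carbonyl carbon, and none covers the loss of hydrogen-bond donors there. A step back toward a lower number is therefore expected with wide uncertainty, estimated as a 2.3-fold lower number from compound 3 to compound 4 (0.37 log units; beyond the scatter). Compound 4 is estimated at 8000 nM, within 2500 nM to 25000 nM in this assay.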

Compound 4, half-maximal inhibitory concentration: 7330 nM
Beside the measured number, compound 4's estimate is 1.1-fold (0.04 log units) above it, and the stated range covers the measured number.
By their numbers in this assay, from the lowest: compound 1; then compound 4; then compounds 3 and 2 (each within the scatter of the next).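

In this assay, among the compounds shown here, a ring-bearing group with no hydrogen-bond donors on the carbonyl carbon separates from the small nitrogen groups, as a 2.5-fold lower number from compound 3 to compound 4 (0.40 log units; beyond the scatter) and a 3.7-fold lower number from compound 2 to compound 4 (0.56 log units; beyond the scatter) show; the earlier compounds showed only the drop from the 4-chlorophenyl and no change between the two small nitrogen groups. The group does not match the 4-chlorophenyl, however, with a 2.8-fold higher number from compound 1 to compound 4 (0.44 log units; beyond the scatter), so at this position two groups with the same count of 7 heavy atoms still give clearly different numbers, and heavy-atom count alone does not set the read-out across compound 1 and compound 4. Nothing available here accounts for this order of the groups.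

The ring, the loss of hydrogen-bond donors and the ring's methyl group all change together in the step to compound 4, so their separate contributions remain unresolved. A piperidine amide or an acetyl hydrazide on the carbonyl carbon would help separate them, while an unsubstituted phenyl there would show how much of the low number of compound 1 depends on the chlorine.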